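The compounds below may be only part of what the source reports. "The series", "measured", "known", "first", "only" and "open" are said of these compounds alone.

Measured compounds:
compound 1, `CC1(C)[C@H]2CC[C@]1(C)N(Cc1cn(-c3ccc(C#N)cc3)nn1)C(=O)C2`, 50 nM
compound 2, `CC1(C)[C@H]2CC[C@]1(C)N(Cc1cn(-c3ccccc3Cl)nn1)C(=O)C2`, 60 nM
compound 3, `Cc1ccc(-n2cc(CN3C(=O)C[C@@H]4CC[C@@]3(C)C4(C)C)nn2)cc1`, 480 nM

In a functional assay on HepG2 cells (Homo sapiens) for inhibition, read by MTT assay, with a stated time of 24 h (a lower number here means a stronger inhibitor, a higher number a weaker inhibitor), compound 1 gives the lowest of the three numbers. Its nearest neighbour is compound 2, and that step, a 1.2-fold higher number from compound 1 to compound 2 (0.08 log units; within the scatter), lies within the scatter, so no order between the two is claimed. The step to compound 3, a 9.6-fold higher number from compound 1 to compound 3 (0.98 log units; beyond the scatter), is beyond the scatter, as is an 8.0-fold higher number from compound 2 to compound 3 (0.90 log units; beyond the scatter).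

The account now follows compound 1 to compound 4, `CC1(C)[C@H]2CC[C@]1(C)N(Cc1cn(-c3ccc(Cl)cc3)nn1)C(=O)C2`, which has not yet been measured in this assay. The change is

chloro in place of cyano on an aromatic carbon

For the measured compounds named here, two measured steps bear on it. Replacing cyano by methyl on the same aromatic carbon, from compound 1 to compound 3, raised the number modestly, while moving to a 2-chlorophenyl, from compound 1 to compound 2, changed nothing beyond the scatter. Removing the cyano group therefore seems the side of the change that matters, and a modest rise is expected, smaller than the step to compound 3 since chloro, not methyl, enters.

Compound 4 is estimated at 150 nM, in a range from 50 nM to 450 nM, which means an expected step of a 3.0-fold higher number from compound 1 to compound 4 (0.48 log units; beyond the scatter).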

Compound 4, half-maximal inhibitory concentration: 90 nM
Estimate against measurement, compound 4: 1.7-fold (0.22 log units) above; the measured number falls inside the stated range.
By their numbers in this assay, from the lowest: compounds 1, 2 and 4 (each within the scatter of the next); then compound 3.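

At this aromatic carbon, chloro can take the place of cyano without a shift beyond the scatter in this assay (a 1.8-fold higher number from compound 1 to compound 4 (0.26 log units; within the scatter)), so the loss of the cyano group alone does not account for the higher number seen with methyl. The group that enters matters here, as chloro in place of methyl gives a clear change (a 5.3-fold lower number from compound 3 to compound 4 (0.73 log units; beyond the scatter)), leaving compound 3 as the only one of the four set apart from the others. The 4-chlorophenyl and 2-chlorophenyl groups also cannot be told apart (a 1.5-fold higher number from compound 2 to compound 4 (0.18 log units; within the scatter)).

No supporting measurement explains why methyl differs from chloro and cyano. Going by these compounds, whether an amine, a carboxylic acid or a methoxy group at this aromatic carbon would follow chloro or methyl remains open.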